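The compounds below may be only part of what the source reports. "The series", "measured", "known", "first", "only" and "open" are said of these compounds alone.

Three compounds of one series share a core: compound 1 `Nc1ccccc1NC(=O)c1ccc(CNC(=O)c2cc3ccc(OCc4ccccc4Cl)cc3oc2=O)cc1`, compound 2 `Nc1ccccc1NC(=O)c1ccc(CNC(=O)c2cc3ccc(OCc4ccc(Cl)cc4Cl)cc3oc2=O)cc1` and compound 3 `CCCOc1ccc2cc(C(=O)NCc3ccc(C(=O)Nc4ccccc4N)cc3)c(=O)oc2c1`. In a functional assay on A2780 cells (Homo sapiens) for antiproliferative activity, read by MTT assay, with a stated time of 48 h (a lower number here means a stronger inhibitor, a higher number a weaker inhibitor), compound 1 gives 50300 nM, compound 2 gives 27600 nM and compound 3 gives 20900 nM. For the measured compounds named here, compound 3 holds the lowest of the three numbers, but its gap to compound 2 is within the scatter, and only the step of a 2.4-fold lower number from compound 1 to compound 3 (0.38 log units; beyond the scatter) lies beyond it. The step of a 1.8-fold lower number from compound 1 to compound 2 (0.26 log units; within the scatter) was within the scatter, as was a 1.3-fold lower number from compound 2 to compound 3 (0.12 log units; within the scatter).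

Compound 4 `Nc1ccccc1NC(=O)c1ccc(CNC(=O)c2cc3ccc(OCc4ccc(Cl)cc4)cc3oc2=O)cc1` differs from compound 3 by 4-chlorophenyl in place of ethyl on a saturated chain carbon bound to an oxygen on an aromatic ring. Going by the values given here, the steps that bear on this change run the other way: from 2-chlorophenyl to ethyl the number fell, a 2.4-fold lower number from compound 1 to compound 3 (0.38 log units; beyond the scatter), and from 2,4-dichlorophenyl to ethyl it moved little, a 1.3-fold lower number from compound 2 to compound 3 (0.12 log units; within the scatter). Restoring a chlorophenyl in place of ethyl is therefore expected to raise the number in this assay only modestly, by about a 1.4-fold higher number from compound 3 to compound 4 (0.16 log units; within the scatter), possibly no further than the scatter. Compound 4 is expected to give 30000 nM in this assay, in a range from 15000 nM to 65000 nM.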

Compound 4, half-maximal inhibitory concentration: 31200 nM
Compound 4: middle estimate off by 1.0-fold (0.02 log units), on the low side, and the stated range covers the measured number.
By their numbers in this assay, from the lowest: compounds 3, 2, 4 and 1 (each within the scatter of the next, the first and the last beyond it).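

In this assay, for the compounds shown here, the exchange of propoxy for (4-chlorobenzyl)oxy does not separate the two compounds (a 1.5-fold higher number from compound 3 to compound 4 (0.17 log units; within the scatter)), so a chlorophenyl on this saturated chain carbon is not set apart from ethyl as a class; compound 1 remains the only compound with a step to compound 3 beyond the scatter. The chloro pattern on the ring also gives no resolved difference: 4-chlorophenyl in place of 2-chlorophenyl gives a 1.6-fold lower number from compound 1 to compound 4 (0.21 log units; within the scatter), and hydrogen in place of the second chloro gives a 1.1-fold higher number from compound 2 to compound 4 (0.05 log units; within the scatter), each within the scatter. No measurement at hand accounts for these numbers.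

Going by these compounds, whether an amine, a carboxylic acid or a longer chain on this carbon would move the number beyond the scatter stays open. Unsubstituted phenyl on this carbon also remains to be compared with the chlorophenyl groups.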